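Pyrimidinylamino-tolyl series: oxadiazole in place of triazole

The compounds below may be only part of what the source reports. "The series", "measured", "known", "first", "only" and "open" are said of these compounds alone.

Measured in a functional assay on K562 cells (Homo sapiens) for inhibition, read by MTT assay, with a stated time of 72 h; on this read-out higher numbers stand for weaker inhibition and lower numbers for stronger inhibition:
compound 1, `Cc1ccc(-n2cc(-c3cc(C(F)(F)F)cc(C(F)(F)F)c3)nn2)cc1Nc1nccc(-c2cccnc2)n1`: 2650 nM
compound 2, `COc1ccc(-c2cn(-c3ccc(C)c(Nc4nccc(-c5cccnc5)n4)c3)nn2)cc1C(F)(F)F`: 11200 nM
compound 3, `Cc1ccc(-n2cc(C(C)O)nn2)cc1Nc1nccc(-c2cccnc2)n1`: 15300 nM

Compound 3 shows the highest number of the three, within the scatter of compound 2 and beyond it against compound 1. Compound 4, `Cc1nnc(-c2ccc(C)c(Nc3nccc(-c4cccnc4)n3)c2)o1`, differs from compound 3 in one place: 5-methyl-1,3,4-oxadiazol-2-yl in place of 4-(1-hydroxyethyl)-1H-1,2,3-triazol-1-yl on an aromatic carbon. Among the compounds with values here, the only measured step in this part of the molecule, a 1.4-fold higher number from compound 2 to compound 3 (0.14 log units; within the scatter), stayed within the scatter, but it did not touch the five-membered ring itself, so no measured step bears directly on the change. The expected step of a 1.3-fold lower number from compound 3 to compound 4 (0.11 log units; within the scatter) is therefore none beyond the scatter. For compound 4 the estimate in this assay is 12000 nM, with a range from 3500 nM to 40000 nM.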

Compound 4, half-maximal inhibitory concentration: > 30000 nM
Compound 4 was reported as a limit (the forecaster's own chance of this, stated with the estimate: 15%); middle value at least 2.5-fold (0.39 log units) away from the limit.
By their numbers in this assay, from the lowest: compound 1; then compounds 2 and 3 (each within the scatter of the next). At a limit, above all of these: compound 4.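

Compound 4 sits at a limit and not at a number: the limit of > 30000 nM in this assay, at which 1 of the 4 values shown sits. Within the data shown here, the only measured change of the five-membered ring itself at this position gives an at least 1.9-fold higher number from compound 3 to compound 4 (0.29 log units; that floor lies within the scatter), so the true size of the step remains unknown and a step beyond the scatter is not established. Even so, 5-methyl-1,3,4-oxadiazol-2-yl brings no lower number than 4-(1-hydroxyethyl)-1H-1,2,3-triazol-1-yl in this assay.

Ring and substituent change together in this step, so their separate contributions remain open. Also open, going by these compounds, is how an amine or a carboxylic acid on the five-membered ring would read.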